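Chloro in place of hydrogen: from compound 1 to compound 3

A few compounds are considered here, and "the series" means these few. Any claim that something is new, unique, unknown or untested is made for them only; others in the source may bear on it.

Measured so far:
compound 1, `Cc1nnc(CN(C)C)n1-c1ccc(Cl)cc1C(=O)c1ccccc1`: 0.5 mg/kg
compound 2, `CNCc1nnc(C)n1-c1ccc(Cl)cc1C(=O)c1ccccc1`: 0.1 mg/kg

In a functional assay on the whole organism (strain CF-1) for inhibition, with Mus musculus as the target (on this read-out lower numbers stand for an effect already at smaller amounts and higher numbers for an effect only at larger amounts of compound), compound 1 gives 0.5 mg/kg, the higher of the two numbers recorded so far. Among the measured compounds shown here, only one other compound has been measured, and the step of a 5.0-fold lower number from compound 1 to compound 2 (0.70 log units; beyond the scatter) came with hydrogen in place of methyl on an amine nitrogen.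

Compound 3, `Cc1nnc(CN(C)C)n1-c1ccc(Cl)cc1C(=O)c1ccccc1Cl`, differs from compound 1 by chloro in place of hydrogen on an aromatic carbon, ortho to a large group; cut one bond further out, the change reads phenyl to 2-chlorophenyl. For the measured compounds named here, no measured step touches this part of the molecule; the single recorded step concerns an amine nitrogen and carries no information about a chloro group on an aromatic ring. With nothing to lean on, the expected step of a 1.3-fold lower number from compound 1 to compound 3 (0.10 log units; within the scatter) is taken to stay within the scatter. Compound 3 is therefore estimated at 0.4 mg/kg in this assay, with a range from 0.1 mg/kg to 1.5 mg/kg.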

Compound 3, dose for half-maximal effect: 0.14 mg/kg
The estimate for compound 3 lay 2.9-fold (0.46 log units) above the measured number, within the range that was stated.
By their numbers in this assay, from the lowest: compounds 2 and 3 (each within the scatter of the next); then compound 1.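

In this assay, the change from phenyl to 2-chlorophenyl gives a 3.6-fold lower number from compound 1 to compound 3 (0.55 log units; beyond the scatter). Among the compounds shown here, this is the first sign in these compounds that the number responds to a change on this aromatic ring, at a carbon ortho to a large group, and not only to a change on the amine nitrogen. Nothing at hand accounts for the size of this step or says what the chloro group does there.

As far as these compounds go, it remains open whether fluoro, methyl or methoxy on the same carbon would shift the number as chloro does. From the compounds shown here alone, it is also open whether chloro would give a similar step on compound 2, which carries hydrogen in place of methyl on the amine nitrogen, or whether the two changes would not add up.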